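This account rests on a few compounds, and the source may have more. Where it says the series, first, only, none or still open, it means among the compounds named here.

Measured in a functional assay on A-431 cells (Homo sapiens) for cytotoxicity, read by MTT assay, with a stated time of 48 h; on this read-out lower numbers stand for stronger inhibition and higher numbers for weaker inhibition:

Compound 1 `CCCCCCCCCCCCNC(=O)[C@@H](NC(=O)c1cc2ccccc2[nH]1)[C@@H](C)O` gives 10300 nM.
Compound 2 `CCCCCCCCCCCCNC(=O)[C@@H](NC(=O)c1cc2ccccc2n1C)[C@@H](C)O` gives 169000 nM.
Compound 3 `CCCCCCCCCCCCCCCCCCNC(=O)[C@@H](NC(=O)c1cc2ccccc2[nH]1)[C@@H](C)O` gives 81000 nM.

Compound 2 differs from compound 1 by methyl in place of hydrogen on an aromatic nitrogen, and that change brought a 16-fold higher number from compound 1 to compound 2 (1.22 log units; beyond the scatter). Compound 3 differs from compound 1 by hexyl in place of hydrogen on a saturated chain carbon, ten or more bonds along the chain from an amide-type nitrogen, which brought a 7.9-fold higher number from compound 1 to compound 3 (0.90 log units; beyond the scatter). Compound 4 `CCCCCCCCCCCCCCCCCCNC(=O)[C@@H](NC(=O)c1cc2ccccc2n1C)[C@@H](C)O` is not yet measured; it differs from compound 3 by methyl in place of hydrogen on an aromatic nitrogen, the same change already seen between compound 1 and compound 2, made in the same place. Among the measured compounds shown here, only that one earlier step is available to judge it, and it was large and beyond the scatter. For compound 4 the expected step is a 12-fold higher number from compound 3 to compound 4 (1.09 log units; beyond the scatter) in this assay, resting on the step from compound 1 to compound 2 of a 16-fold higher number from compound 1 to compound 2 (1.22 log units; beyond the scatter) and on compound 3 at 81000 nM. Compound 4 is therefore estimated at 1000000 nM, between 350000 nM and 3000000 nM.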

Compound 4, half-maximal inhibitory concentration: 61000 nM
Beside the measured number, compound 4's estimate is 16-fold (1.21 log units) above it, outside the stated range (below it).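

With the longer chain of compound 3, methyl in place of hydrogen on the aromatic nitrogen gives a 1.3-fold lower number from compound 3 to compound 4 (0.12 log units; within the scatter), so the large step seen on the core of compound 1 does not carry over: the same change on two cores in this assay, a 16-fold higher number (1.22 log units; beyond the scatter) from compound 1 to compound 2 and a 1.3-fold lower number (0.12 log units; within the scatter) from compound 3 to compound 4, 22-fold (1.34 log units) apart, beyond the scatter of two such steps

Adding hexyl to the chain likewise depends on what sits on that nitrogen, since it gives a 2.8-fold lower number from compound 2 to compound 4 (0.44 log units; beyond the scatter), in the opposite direction to the earlier step: the same change on two cores in this assay, a 7.9-fold higher number (0.90 log units; beyond the scatter) from compound 1 to compound 3 and a 2.8-fold lower number (0.44 log units; beyond the scatter) from compound 2 to compound 4, 22-fold (1.34 log units) apart, beyond the scatter of two such steps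

These four compounds show that the two changes do not act independently here, but they do not show why, or how far this holds beyond these compounds.

Still open, on these data alone, is how the numbers would move with a decyl chain, or with ethyl on the aromatic nitrogen.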